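The source may report more compounds than this note shows. Statements on the series, on what has been measured and on what is new or still open speak of the compounds shown alone.

Values so far in a functional assay on MCF7 cells (Homo sapiens) for cytotoxicity, read by sulforhodamine B assay; on this read-out higher numbers stand for weaker inhibition of growth and lower numbers for stronger inhibition of growth
Compound 1 `CC1=CC[C@@H]([C@@](C)(O)CCCC(C)(C)NC(=S)NN)CC1` gives 15300 nM
Compound 2 `CC1=CC[C@@H]([C@@](C)(O)CCCC(C)(C)NC(=S)N/N=C\c2ccc(O)cc2)CC1` gives 6230 nM
Compound 3 `CC1=CC[C@@H]([C@@](C)(O)CCCC(C)(C)NC(=S)N/N=C\c2cccc([N+](=O)[O-])c2)CC1` gives 6720 nM

Compound 3 sits level with compound 2 and has a lower number than compound 1, which has the highest number of the three.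

The next compound, compound 4 `CC1=CC[C@@H]([C@@](C)(O)CCCC(C)(C)NC(=S)N/N=C\c2ccc(Cl)cc2)CC1`, differs from compound 3 in one place: 4-chlorophenyl in place of 3-nitrophenyl on a carbon with a double bond to nitrogen. In words, this is 4-chlorophenyl in place of 3-nitrophenyl on a carbon with a double bond to nitrogen.

Among the measured compounds shown here, two measured steps bear on this change. The closest is the swap of one substituted phenyl for another on that same carbon, which gave a 1.1-fold higher number from compound 2 to compound 3 (0.03 log units; within the scatter) and so no real difference. The other is the addition of the whole aromatic group, which gave a 2.5-fold lower number from compound 1 to compound 2 (0.39 log units; beyond the scatter) and remains modest. Compound 4 keeps that aromatic ring. For the measured compounds named here, no measured compound carries chlorine, so the comparison rests on two ring variants only.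

In this assay an estimated step of a 1.0-fold lower number from compound 3 to compound 4 (0.01 log units; within the scatter) is therefore expected, with no change beyond the scatter. Compound 4 is estimated at 6500 nM and expected between 3200 nM and 13000 nM.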

Compound 4, concentration for 50% growth inhibition: 6890 nM
The estimate for compound 4 lay 1.1-fold (0.03 log units) below the measured number; the measured number falls inside the stated range.
By their numbers in this assay, from the lowest: compounds 2, 3 and 4 (each within the scatter of the next); then compound 1.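

In this assay, a ring carrying chloro now stands on the carbon with a double bond to nitrogen, and it matches both earlier rings: 4-chlorophenyl in place of 3-nitrophenyl gives a 1.0-fold higher number from compound 3 to compound 4 (0.01 log units; within the scatter), and chloro in place of hydroxy on an aromatic carbon gives a 1.1-fold higher number from compound 2 to compound 4 (0.04 log units; within the scatter). Adding the aromatic group to the end of the chain remains the only change that moves the number beyond the scatter, and with chloro on the ring that modest step is a 2.2-fold lower number from compound 1 to compound 4 (0.35 log units; beyond the scatter). No measurement here explains why hydroxy, nitro and chloro rings sit level.

On these data alone, it remains open whether a ring carrying an amine or a carboxylic acid would also sit level. A longer alkyl chain on this carbon, with no aromatic ring, could show whether the ring itself is needed for the step.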